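The source may hold more compounds than are shown below. What is called first, only, known or untested is meant among the compounds shown, and "the series" means these compounds.

In a functional assay on L6 cells (Rattus norvegicus) for inhibition (a higher number here means a weaker inhibitor, a lower number a stronger inhibitor), two compounds have been measured. Compound 1 (`CC(C)c1c(C(=O)N(C)Cc2cccc(F)c2)nn(-c2ccc(F)cc2)c1CC[C@@H](O)C[C@@H](O)CC(=O)O`) gives 1900 nM and compound 2 (`CC(C)c1c(C(=O)NCc2ccccc2)nn(-c2ccc(F)cc2)c1OC[C@@H](O)C[C@@H](O)CC(=O)O`) gives 880 nM as the lower of the two numbers. That gap lies beyond the usual scatter, so compound 2 stands as the stronger inhibitor of this pair. The account now moves to compound 3 (`Cc1cccc(CNC(=O)c2nn(-c3ccc(F)cc3)c(OC[C@@H](O)C[C@@H](O)CC(=O)O)c2C(C)C)c1`), which keeps compound 2 unchanged except in one place. The difference is methyl in place of hydrogen on an aromatic carbon and amounts to methyl in place of hydrogen on an aromatic carbon, meta to a large group, turning benzyl into 3-methylbenzyl. Within the data shown here, the two measured compounds differ from each other in more than one place, so no measured step shows what this change does in this assay and no direction can be firmly expected. For so small an addition, the expectation is no shift beyond the scatter, starting from compound 2 at 880 nM as the anchor. The expected step of a 1.1-fold lower number from compound 2 to compound 3 (0.04 log units; within the scatter) is correspondingly slight. Compound 3 is estimated to read 800 nM (expected range 320 nM to 2000 nM).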

Compound 3, half-maximal inhibitory concentration: 280 nM
For compound 3 the middle estimate is 2.9-fold (0.46 log units) above the measured one; measured number outside the range, below it.
By their numbers in this assay, from the lowest: compound 3; then compound 2; then compound 1.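

In this assay, among these compounds, the change from benzyl to 3-methylbenzyl gives a 3.1-fold lower number from compound 2 to compound 3 (0.50 log units; beyond the scatter) and is the first single-place change that can be read. It shows that the aromatic ring of the benzyl group responds to substitution at this carbon: a single added methyl, with no ring, no hydrogen-bond donors or acceptors and no net charge, is enough to carry the number beyond the scatter, towards a stronger inhibitor, something the two earlier compounds could not show since they differ from each other in more than one place. Nothing in the information at hand accounts for this step.

Whether the gain is particular to methyl stays open, since the compounds shown say nothing about what ethyl, methoxy, chlorine or trifluoromethyl would do at this same carbon. From the compounds shown here alone, it is equally open whether a methyl on another carbon of that ring would move the number in the same direction, or whether a second methyl added to compound 3 would move it further.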